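The compounds below may be only part of what the source reports. "The series", "measured", "known", "first", "only" and "open" are said of these compounds alone.

In a physicochemical assay for solubility, using the shake flask method, in simulated intestinal fluid, measured as kinetic solubility, with a stated time of 2 h, at 25 degrees C, at pH 6.5 (a higher number here means a more soluble compound, a lower number a less soluble compound), compound 1 `Cc1noc(-c2nc(C)c3c(c2N)C(=O)N(Cc2ccccc2)C3=O)n1` gives < 5000 nM, which is a limit of the assay and not a number. Compound 2 `Cc1noc(-c2nc(C)c3c(c2N)C(=O)N(Cc2ccc(Cl)cc2)C3=O)n1` gives < 5000 nM, again a limit. Compound 3 `Cc1noc(-c2nc(C)c3c(c2N)C(=O)N(Cc2ccc(Br)cc2)C3=O)n1` gives < 5000 nM, also a limit, so its place can be stated only in those terms. The whole picture so far is the limit of < 5000 nM in this assay, at which 3 of the 3 values shown sit.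

Compound 4 `Cc1noc(-c2nc(C)c3c(c2N)C(=O)N(Cc2cccc(C(F)(F)F)c2)C3=O)n1` carries 3-(trifluoromethyl)phenyl in place of the 4-bromophenyl of compound 3, on a saturated chain carbon bound to an amide-type nitrogen in a ring: 3-(trifluoromethyl)phenyl in place of 4-bromophenyl on a saturated chain carbon bound to an amide-type nitrogen in a ring.

For the measured compounds named here, three measured steps bear on this change, as each alters a substituent on that aromatic ring. They are a step that the two limits leave unreadable from compound 1 to compound 2, a step that the two limits leave unreadable from compound 1 to compound 3 and a step that the two limits leave unreadable from compound 2 to compound 3. None has a readable size, so they offer neither a magnitude nor a direction to carry over. With nothing pointing either way, no step beyond the scatter is expected in this assay, and compound 4 will most likely be reported as a limit again. The expected change is a step that the limit leaves unreadable from compound 3 to compound 4. For compound 4 the estimate is 2500 nM, with an expected range from 800 nM to 5000 nM.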

Compound 4, solubility: < 5000 nM
Compound 4 was reported as a limit; the forecaster's own chance of this, stated with the estimate: 85%; the middle value does not contradict the limit.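

Compound 4 also gives a limit and not a number, so in this assay its steps from compound 1, compound 2 and compound 3 cannot be read, and all four compounds stand at one place: the limit of < 5000 nM in this assay, at which 4 of the 4 values shown sit.

The compounds shown leave open how far each one lies from that limit, and whether their different aromatic ring substituents separate them at all.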